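Trimethoxyphenyl triazoles: a methylsulfanyl replaces chloro

The compounds below may be only part of what the source reports. "The series", "measured", "known", "first", "only" and "open" are said of these compounds alone.

Compound 1 `COc1cc(-c2ncnn2-c2ccc(Cl)cc2Cl)cc(OC)c1OC` — > 10000 nM
Compound 2 `COc1cc(-n2ncnc2-c2ccc(Cl)cc2)cc(OC)c1OC` — > 10000 nM
Compound 3 `COc1cc(-c2ncnn2-c2ccc(Cl)cc2)cc(OC)c1OC` — > 10000 nM

All three measured compounds were tested in a functional assay on MCF7 cells (Homo sapiens) for antiproliferative activity, read by MTT assay, with a stated time of 72 h; on this read-out higher numbers stand for weaker inhibition and lower numbers for stronger inhibition. Compound 1 reached only the limit of the assay, > 10000 nM. Compound 2 likewise gave only a limit, > 10000 nM. Compound 3 also returned only a limit, > 10000 nM. Among the compounds with values here, the one single-point step, a step that the two limits leave unreadable from compound 1 to compound 3, is therefore unreadable, as both ends sit at the limit of > 10000 nM in this assay, at which 3 of the 3 values shown sit.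

Compound 4 `COc1cc(-n2ncnc2-c2ccc(SC)cc2)cc(OC)c1OC` differs from compound 2 by methylsulfanyl in place of chloro on an aromatic carbon. Within the data shown here, no measured step involves a methylsulfanyl group, so nothing here speaks for a change beyond the scatter. Compound 4 is expected to remain near the limit, 10000 nM (range 3000 nM to 30000 nM), meaning an estimated step of a number no higher from compound 2 to compound 4 (the limit leaves the size open).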

Compound 4, half-maximal inhibitory concentration: 390 nM
Compound 4: middle estimate off by 26-fold (1.41 log units), on the high side; the whole stated range lies above it.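

Methylsulfanyl in place of chloro, para to a large group, gives the first readable step in this assay, an at least 25-fold lower number from compound 2 to compound 4 (1.40 log units; beyond the scatter). So this position on the aromatic ring can carry a large change in the read-out, which the chloro compounds could not show. Compound 4 is the only compound shown that comes off the limit of the assay: the limit of > 10000 nM in this assay, at which 3 of the 4 values shown sit.

The compounds shown leave open whether the same change would act on the core of compound 3. They also leave open how an ethylsulfanyl, a methoxy or an amine in this place would read.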